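Methoxycarbonyl in place of furan-2-yl: notes on compound 4

A few compounds are considered here, and "the series" means these few. Any claim that something is new, unique, unknown or untested is made for them only; others in the source may bear on it.

compound 1 `COc1cc(/C=C/C(=O)c2cccc(NC(=O)c3ccc(Cl)cc3)c2)ccc1O`: > 50 ug/mL (a limit of the assay)
compound 2 `COc1cc(/C=C/C(=O)c2cccc(NC(=O)c3ccco3)c2)ccc1O`: 6.65 ug/mL
compound 3 `COc1cc(/C=C/C(=O)c2cccc(N)c2)ccc1O`: 7.71 ug/mL

In a functional assay on U-87MG ATCC cells (Homo sapiens) for inhibition (a higher number here means a weaker inhibitor, a lower number a stronger inhibitor), compound 2 gives 6.65 ug/mL. Within the data shown here, its only numerical neighbour is compound 3, with a 1.2-fold higher number from compound 2 to compound 3 (0.06 log units; within the scatter). The value of compound 1 is a limit of the assay, not a number.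

Compound 4 `COC(=O)C(=O)Nc1cccc(C(=O)/C=C/c2ccc(O)c(OC)c2)c1` is the next case, with this change: methoxycarbonyl in place of furan-2-yl on a carbonyl carbon. In words, methoxycarbonyl stands in place of furan-2-yl on a carbonyl carbon. Among the measured compounds shown here, two measured steps bear on it. Exchange at this same carbon can matter, as an at least 7.5-fold lower number from compound 1 to compound 2 (0.87 log units; beyond the scatter) shows. Removing the whole acyl group can leave the reading unmoved, as a 1.2-fold higher number from compound 2 to compound 3 (0.06 log units; within the scatter) shows. For the measured compounds named here, no measured compound carries a group without a ring here, so the direction is only weakly supported. A small move toward a higher number, not clearly beyond the scatter, is expected. The expected step is a 1.5-fold higher number from compound 2 to compound 4 (0.18 log units; within the scatter). For compound 4 the estimated value is 10 ug/mL. The expected range for compound 4 runs from 4 ug/mL to 35 ug/mL.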

Compound 4, half-maximal inhibitory concentration: 12.2 ug/mL
Compound 4: the middle estimate sits 1.2-fold (0.09 log units) below what was measured, within the range that was stated.
By their numbers in this assay, from the lowest: compounds 2, 3 and 4 (each within the scatter of the next). At a limit, above all of these: compound 1.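

In this assay a group without a ring on this carbonyl carbon now has a reading: a 1.8-fold higher number from compound 2 to compound 4 (0.26 log units; within the scatter) is what methoxycarbonyl in place of furan-2-yl gives, so a ring at this place is not required for a reading in the range of compound 2. Against the free amine, a 1.6-fold higher number from compound 3 to compound 4 (0.20 log units; within the scatter) is the step for adding (methoxycarbonyl)carbonyl on the nitrogen, so compound 2, compound 3 and compound 4 cannot be ordered. Compound 1 alone stands apart, with an at least 4.0-fold lower number from compound 1 to compound 4 (0.61 log units; beyond the scatter) as its step to the new group, and its reading is a limit of the assay, not a number: the limit of > 50 ug/mL in this assay, at which 1 of the 4 values shown sits.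

Going by these compounds, what a carboxylic acid, a dimethylamino group or a longer alkyl chain on this carbonyl carbon would give stays open. Also open, on these data alone, is whether an unsubstituted phenyl here would read like compound 1 or like the furan-2-yl of compound 2.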